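Replacing cyclopropyl with 2-ethoxyphenyl on the amine nitrogen

This account rests on a few compounds, and the source may have more. Where it says the series, first, only, none or still open, it means among the compounds named here.

Measured in a functional assay on MCF7 cells (Homo sapiens) for inhibition, read by sulforhodamine B assay; on this read-out higher numbers stand for weaker inhibition and lower numbers for stronger inhibition:
Compound 1 `O=C1C(Nc2ccccc2F)=CC(=O)c2c1nc1n2[C@H]2OC[C@@H](O)[C@H]2OC1`: > 4000 nM, a limit
Compound 2 `CCc1ccc(NC2=CC(=O)c3c(nc4n3[C@H]3OC[C@@H](O)[C@H]3OC4)C2=O)cc1`: 8990 nM
Compound 3 `O=C1C(NC2CC2)=CC(=O)c2c1nc1n2[C@H]2OC[C@@H](O)[C@H]2OC1`: > 16000 nM, a limit

Compound 3 gives no number, only a limit: the limit of > 16000 nM in this assay, at which 1 of the 3 values shown sits. Compound 1 also gives only a limit: the limit of > 4000 nM in this assay, at which 1 of the 3 values shown sits. Within the data shown here, compound 2 is therefore the only compound with a measured number.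

Compound 4 `CCOc1ccccc1NC1=CC(=O)c2c(nc3n2[C@H]2OC[C@@H](O)[C@H]2OC3)C1=O` carries 2-ethoxyphenyl in place of cyclopropyl on an amine nitrogen.

The most informative measured step is an at least 1.7-fold higher number from compound 2 to compound 3 (0.25 log units; that floor lies within the scatter). It exchanges 4-ethylphenyl for cyclopropyl at the same place, and its floor does not establish a difference beyond the scatter. The other two steps give no size: a step that the limit leaves unreadable from compound 1 to compound 2 and a step that the two limits leave unreadable from compound 1 to compound 3. A lower number is expected in this assay, by a modest and poorly defined amount, and a further limit remains possible. Compound 2 at 8990 nM anchors this expectation. The estimated step is an at least 2.0-fold lower number from compound 3 to compound 4 (0.30 log units; that floor lies within the scatter). Compound 4 is estimated at 8000 nM, with an expected range from 2500 nM to 25000 nM.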

Compound 4, half-maximal inhibitory concentration: > 4000 nM
Compound 4 gave a limit, no number (the forecaster's own chance of this, stated with the estimate: 35%); the middle value does not contradict the limit.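

In this assay compound 4 gives > 4000 nM, a limit and not a number. Among these compounds, no step to compound 4 from compound 1, compound 2 or compound 3 can be read. Left open is whether 2-ethoxyphenyl on the amine nitrogen differs at all from the other three groups.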